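Compound 3 stands out from its two open-chain relatives

The source may hold more compounds than are shown below. What is called first, only, known or untested is meant among the compounds shown, and "the series" means these compounds.

Values in an ADME assay on A549 cells (Homo sapiens) for cytotoxicity, read by resazurin assay, with a stated time of 48 h; a higher number here means that more compound is tolerated, a lower number that less compound is tolerated:
compound 1 `CCCNc1ccc(NC(=O)c2cc(Cl)ccc2O)c(Cl)c1` gives 22500 nM
compound 2 `CCCCCCC(C)Nc1ccc(NC(=O)c2cc(Cl)ccc2O)c(Cl)c1` gives 23500 nM
compound 3 `CC1(Nc2ccc(NC(=O)c3cc(Cl)ccc3O)c(Cl)c2)CCCC1` gives 157000 nM

Compound 3 is the highest of the three measured. The change to compound 4 `CN(C)c1ccc(NC(=O)c2cc(Cl)ccc2O)c(Cl)c1` is dimethylamino in place of (1-methylcyclopentyl)amino on an aromatic carbon and puts a group with no ring on that aromatic carbon. Among the compounds with values here, three measured steps bear on it. Lengthening propyl to 1-methylheptyl gave a 1.0-fold higher number from compound 1 to compound 2 (0.02 log units; within the scatter) and moved nothing beyond the scatter. Bringing in 1-methylcyclopentyl gave a 7.0-fold higher number from compound 1 to compound 3 (0.84 log units; beyond the scatter) and also a 6.7-fold higher number from compound 2 to compound 3 (0.82 log units; beyond the scatter) as modest rises. Within the data shown here, neither compound 1 nor compound 2 has a ring in that group, so a modest fall is expected, though no measured compound carries dimethylamino. The estimated change is a 4.9-fold lower number from compound 3 to compound 4 (0.69 log units; beyond the scatter) in this assay and it points towards less compound tolerated. Compound 4 is estimated at 32000 nM with 11000 nM to 120000 nM as its expected range.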

Compound 4, half-maximal cytotoxic concentration: 85100 nM
Estimate against measurement, compound 4: 2.7-fold (0.42 log units) below; low and high end bracket the measured number.
By their numbers in this assay, from the lowest: compounds 1 and 2 (each within the scatter of the next); then compounds 4 and 3 (each within the scatter of the next).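

In this assay, a ring in this group turns out not to be required for a high number: dimethylamino, which has no ring and no hydrogen-bond donor, gives a 1.8-fold lower number from compound 3 to compound 4 (0.27 log units; within the scatter). Within the data shown here, the same change gives a 3.6-fold higher number from compound 2 to compound 4 (0.56 log units; beyond the scatter) and a 3.8-fold higher number from compound 1 to compound 4 (0.58 log units; beyond the scatter), so groups without a ring do not all behave alike here, and compound 4 goes against the ring-based reading of the earlier compounds. No measurement shown here explains these differences.

As far as these compounds go, how a plain amine or diethylamino on this aromatic carbon would compare remains open.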